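The source may hold more compounds than are shown below. What is called first, only, known or untested is meant among the compounds shown, and "the series" means these compounds.

Working notes on the series. Among the compounds with values here, compound 1 `CC(C)(C)N(NC(=O)c1ccccc1)C(=O)c1ccccc1Cl` and compound 2 `Cc1ccc(C(=O)NN(C(=O)c2ccccc2Cl)C(C)(C)C)cc1C` are the two measured members. In an assay on cells for agonist activity at ecdysone receptor (Bombyx mori), read by a luciferase reporter, with a stated time of 24 h (a higher number here means that more compound is needed for the effect, a lower number that less compound is needed), compound 1 gives 75.9 nM. Compound 2 gives 87.1 nM, and the two numbers lie within the scatter of each other, so compound 1 stands level with compound 2 on what has been measured. Within the data shown here, the only measured step, a 1.1-fold higher number from compound 1 to compound 2 (0.06 log units; within the scatter), concerns the other carbonyl carbon and stays within the scatter, so it does not bear on the change now in question. Compound 3 `CC(C)(C)N(NC(=O)c1ccccc1)C(=O)C1CCCCC1` differs from compound 1 by cyclohexyl in place of 2-chlorophenyl on a carbonyl carbon. Among the measured compounds shown here, no measured step touches this carbonyl carbon, and no non-aromatic ring has been tested anywhere. The expected step for compound 3 is therefore uncertain and is set at a 4.0-fold higher number from compound 1 to compound 3 (0.60 log units; beyond the scatter), toward a higher number. Compound 3 is estimated at 300 nM, with a range from 80 nM to 1500 nM.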

Compound 3, half-maximal effective concentration: 46800 nM
The estimate for compound 3 lay 160-fold (2.19 log units) below the measured number; the whole stated range lies below it.
By their numbers in this assay, from the lowest: compounds 1 and 2 (each within the scatter of the next); then compound 3.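

In this assay, within the data shown here, this carbonyl carbon, whose other neighbour is the amide-type nitrogen, proves highly sensitive to change, with a 620-fold higher number from compound 1 to compound 3 (2.79 log units; beyond the scatter), whereas the only earlier step, a 1.1-fold higher number from compound 1 to compound 2 (0.06 log units; within the scatter), lay at the other carbonyl carbon and showed no such sensitivity. The change from 2-chlorophenyl to cyclohexyl swaps an aromatic ring for a non-aromatic ring and also removes the chlorine, and this single step does not separate those two differences. Nothing at hand explains the size of the step.

On these data alone, whether an unsubstituted phenyl or a 2-methylphenyl on this carbonyl carbon would hold the number near that of compound 1 remains open. Also open, as far as these compounds go, is how a pyridyl ring or a smaller non-aromatic group such as cyclopentyl would fare there.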